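Replacing a carbonyl side chain with a propyl chain

The compounds below may be only part of what the source reports. "The series", "measured", "known", "first", "only" and "open" are said of these compounds alone.

Of the compounds shown here, three with a shared core have been measured in an ADME assay on L6 cells (Rattus norvegicus) for cytotoxicity, read by fluorescence, with a stated time of 72 h; a lower number here means a stronger inhibitor, a higher number a weaker inhibitor. In this test, compound 1 `CCN(CC)C(=O)CNC1CC2(N3CCN(C)CC3)CC(c3ccccc3)C1C(c1ccccc1)C2` gives 37900 nM, compound 2 `CN1CCN(C23CC(NCCC(=O)N4CCCC4)C(C(c4ccccc4)C2)C(c2ccccc2)C3)CC1` gives 21500 nM and compound 3 `CN1CCN(C23CC(NC(=O)CCN4CCCCC4)C(C(c4ccccc4)C2)C(c2ccccc2)C3)CC1` gives 15400 nM. Two steps fix where the last of these stands: a 1.4-fold lower number from compound 2 to compound 3 (0.14 log units; within the scatter), and a 2.5-fold lower number from compound 1 to compound 3 (0.39 log units; beyond the scatter).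

Compound 4 `CN1CCN(C23CC(NCCCN4CCCC4)C(C(c4ccccc4)C2)C(c2ccccc2)C3)CC1` keeps the core, but 3-(pyrrolidin-1-yl)propyl takes the place of (2-(piperidin-1-yl)ethyl)carbonyl on an amine nitrogen: 3-(pyrrolidin-1-yl)propyl in place of (2-(piperidin-1-yl)ethyl)carbonyl on an amine nitrogen. Going by the values given here, every measured compound has a carbonyl in this side chain, so no measured step shows its loss, and the estimate is uncertain.

The nearest evidence comes from earlier side-chain changes, which moved the number only a little: a 1.8-fold lower number from compound 1 to compound 2 (0.25 log units; within the scatter), alongside the two steps above. A small step is therefore expected in this assay, probably within the scatter and slightly downward. The expected change is a 1.3-fold lower number from compound 3 to compound 4 (0.11 log units; within the scatter). For compound 4 the estimated value is 12000 nM, with an expected range of 5000 nM to 30000 nM.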

Compound 4, half-maximal inhibitory concentration: 22600 nM
For compound 4 the middle estimate is 1.9-fold (0.27 log units) below the measured one, within the range that was stated.
By their numbers in this assay, from the lowest: compounds 3, 2, 4 and 1 (each within the scatter of the next, the first and the last beyond it).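

In this assay, going by these compounds alone, this position gives the first look at a side chain with no carbonyl: 3-(pyrrolidin-1-yl)propyl in place of (2-(piperidin-1-yl)ethyl)carbonyl gives a 1.5-fold higher number from compound 3 to compound 4 (0.17 log units; within the scatter), so the carbonyl can go without a step beyond the scatter. The closest view of that loss is (pyrrolidin-1-yl)methyl in place of (pyrrolidin-1-yl)carbonyl, with a 1.1-fold higher number from compound 2 to compound 4 (0.02 log units; within the scatter), and the comparison with the diethylcarbamoyl side chain gives a 1.7-fold lower number from compound 1 to compound 4 (0.22 log units; within the scatter) as well. Nothing measured here offers an explanation for these results.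

A 3-(piperidin-1-yl)propyl chain would separate the loss of the carbonyl from the change of ring in the step between the two compounds. Going by these compounds, whether a longer chain or a carboxylic acid at the chain end would shift the number beyond the scatter remains open.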